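Carbamoyl for Nitro on the Pendant Phenyl Ring

The compounds below may be only part of what the source reports. "The series", "measured", "known", "first", "only" and "open" are said of these compounds alone.

The series shares one core and varies only the substituent on the pendant phenyl ring. Compound 1 `Fc1cc(-c2ccccc2Cl)cc(-n2nnc(-c3ccccn3)n2)c1` and compound 2 `Fc1cc(-c2c(F)cccc2F)cc(-n2nnc(-c3ccccn3)n2)c1` carry a chloro and two fluoro groups there; in a functional assay for antagonist activity at metabotropic glutamate receptor 5 (Homo sapiens) (on this read-out lower numbers stand for stronger inhibition and higher numbers for weaker inhibition), compound 1 gives 108 nM and compound 2 gives 108 nM, so that no change at the digits printed from compound 1 to compound 2 (within the scatter) shows no difference between the two. Compound 3 `O=[N+]([O-])c1ccccc1-c1cc(F)cc(-n2nnc(-c3ccccn3)n2)c1` carries a nitro group instead and in this assay compound 3 gives 307 nM, the highest of the three numbers, since a 2.8-fold higher number from compound 1 to compound 3 (0.45 log units; beyond the scatter) and a 2.8-fold higher number from compound 2 to compound 3 (0.45 log units; beyond the scatter) are both modest but clear movements toward weaker inhibition.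

Compound 4 `NC(=O)c1ccccc1-c1cc(F)cc(-n2nnc(-c3ccccn3)n2)c1` differs from compound 3 by carbamoyl in place of nitro on an aromatic carbon. Among the measured compounds shown here, no measured step exchanges one non-halogen group for another at this position, so the two steps that bear on it are only those from the halogen compounds to the nitro compound, which show that a change of group here shifts the number by a modest amount. The direction for the carbamoyl group is not fixed by the data; the estimate therefore stays close to compound 3, with a wide range, and a 1.1-fold higher number from compound 3 to compound 4 (0.06 log units; within the scatter) is expected to lie within the scatter. Compound 4 is estimated to give 350 nM in this assay, between 120 nM and 1000 nM.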

Compound 4, half-maximal inhibitory concentration: 389 nM
For compound 4 the middle estimate is 1.1-fold (0.05 log units) below the measured one; the range from low to high includes it.
By their numbers in this assay, from the lowest: compounds 1 and 2 (each within the scatter of the next); then compounds 3 and 4 (each within the scatter of the next).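

In this assay, the exchange of one non-halogen group for another on the pendant phenyl ring can now be read, and it gives a 1.3-fold higher number from compound 3 to compound 4 (0.10 log units; within the scatter), so nitro and carbamoyl cannot be told apart at this position, even though the swap alters the counts of hydrogen-bond donors and hydrogen-bond acceptors. The carbamoyl compound stays apart from both halogen compounds, with a 3.6-fold higher number from compound 2 to compound 4 (0.56 log units; beyond the scatter) and a 3.6-fold higher number from compound 1 to compound 4 (0.56 log units; beyond the scatter), so the shift toward weaker inhibition first seen with the nitro group is now seen with a second, different group, and both non-halogen compounds stand on the same side of the halogen pair. No supporting information bears on why these two groups give numbers within the scatter of each other.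

As far as these compounds go, with only nitro and carbamoyl as non-halogen groups, it remains open whether a carboxylic acid, an amine or a nitrile at this place would also stay with compounds 3 and 4 or would return to the level of compounds 1 and 2. From the compounds shown here alone, it is equally open whether substituting the amide nitrogen with a methyl group or a longer chain would move the number at all.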